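The compounds below may be only part of what the source reports. "The series", "measured", "known", "first", "only" and "open" are said of these compounds alone.

Compound 1 `O=S(=O)(Nc1ccc2oc(-c3ccccc3)nc2c1)c1ccccc1O` gives 85000 nM in an assay on cells for inhibition of HSP60/HSP10 (Homo sapiens), with a stated time of 60 min; on this read-out lower numbers stand for stronger inhibition and higher numbers for weaker inhibition. Compound 2 `O=S(=O)(Nc1ccc2oc(-c3ccccc3)nc2c1)c1cccc(C(F)(F)F)c1` reaches only a limit of this assay, > 100000 nM. Compound 3 `C=Cc1ccc(S(=O)(=O)Nc2ccc3oc(-c4ccccc4)nc3c2)cc1` likewise reaches only a limit, > 100000 nM.

Compound 3 thus stands at the edge of what this assay can report, and the limit of > 100000 nM in this assay, at which 2 of the 3 values shown sit, marks where most of these results sit. Among the compounds with values here, the one measured step that touches it runs an at least 1.1-fold higher number from compound 1 to compound 3 (0.07 log units; that floor lies within the scatter), a change too small to read against the scatter and ending at a limit. Compound 4 `O=S(=O)(Nc1ccc2oc(-c3ccccc3)nc2c1)c1cccc(O)c1` is not yet measured; it differs from compound 3 by 3-hydroxyphenyl in place of 4-vinylphenyl on a sulfonyl sulfur. With 2-hydroxyphenyl in compound 1 giving only 85000 nM, no step beyond the scatter is expected here. Compound 4 is expected to give about 100000 nM, ranging from 40000 nM to 250000 nM, an expected step of a number no higher from compound 3 to compound 4 (the limit leaves the size open) within the scatter.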

Compound 4, half-maximal inhibitory concentration: 76000 nM
Beside the measured number, compound 4's estimate is 1.3-fold (0.12 log units) above it; low and high end bracket the measured number.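

In this assay the 3-hydroxyphenyl group on the sulfonyl sulfur gives a measured number where 4-vinylphenyl and 3-trifluoromethylphenyl reach only a limit, with an at least 1.3-fold lower number from compound 3 to compound 4 (0.11 log units; that floor lies within the scatter) and an at least 1.3-fold lower number from compound 2 to compound 4 (0.11 log units; that floor lies within the scatter) as all that can be said of those two changes. The swap of 2-hydroxyphenyl for 3-hydroxyphenyl gives a 1.1-fold lower number from compound 1 to compound 4 (0.05 log units; within the scatter) and so no readable change at this position. The values still gather at one edge of the assay: the limit of > 100000 nM in this assay, at which 2 of the 4 values shown sit.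

On these data alone, whether an amine or a carboxylic acid on this ring would move the number beyond the scatter stays open. So does whether any change to the shared core would.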